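From Propoxy to Hydroxy on the Shared Core

The source may hold more compounds than are shown below. What is called first, only, known or untested is meant among the compounds shown, and "the series" means these compounds.

In an ADME assay on KB cells (Homo sapiens) for cytotoxicity (a higher number here means that more compound is needed for the effect, a lower number that less compound is needed), compound 1 `CCOc1c(OC)c(OC)cc2c1C(=O)[C@]1(OC)C=C[C@H]2N(C(=O)OCC(C)C)N1C(=O)OCC(C)C` gives > 300 ug/mL, which is a limit of the assay and not a number. Going by the values given here, compound 2 `CCCOc1c(OC)c(OC)cc2c1C(=O)[C@]1(OC)C=C[C@H]2N(C(=O)OCC(C)C)N1C(=O)OCC(C)C` reads 299 ug/mL, the only actual number so far. Among the compounds with values here, the one measured step, methyl in place of hydrogen on a saturated chain carbon, two bonds along the chain from an oxygen on an aromatic ring, is a number no higher from compound 1 to compound 2 (the limit leaves the size open). On these data alone, its size stays open, as it rests on (the limit of > 300 ug/mL in this assay, at which 1 of the 2 values shown sits).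

Compound 3 `COc1cc2c(c(O)c1OC)C(=O)[C@]1(OC)C=C[C@H]2N(C(=O)OCC(C)C)N1C(=O)OCC(C)C` carries hydrogen in place of propyl on an oxygen on an aromatic ring, turning propoxy into hydroxy (hydrogen in place of propyl on an oxygen on an aromatic ring). The measured step lengthens a chain rather than removing one, so it bears only loosely on this change and gives no firm size for it. Compound 2, at 299 ug/mL, stands close to the top of what this assay reports, so any real move is expected toward a lower number. The expected change is a 2.0-fold lower number from compound 2 to compound 3 (0.30 log units; within the scatter), a modest and uncertain step. For compound 3 the estimate is 150 ug/mL, with an expected range from 40 ug/mL to 300 ug/mL.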

Compound 3, concentration for half-maximal effect: > 300 ug/mL
Compound 3 gave a limit, no number; the forecaster's own chance of this, stated with the estimate: 30%; middle value at least 2.0-fold (0.30 log units) away from the limit.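

Taking the propyl off the oxygen on the aromatic ring, which turns propoxy into hydroxy, gives a number no lower from compound 2 to compound 3 (the limit leaves the size open). So in this assay the earlier step had only lengthened the chain on this oxygen, whereas this one removes the chain entirely, and the free hydroxy still brings no lower number than the propoxy of compound 2. The size of this step cannot be read, and neither can the step from compound 1 to compound 3, where both ends are limits: the limit of > 300 ug/mL in this assay, at which 2 of the 3 values shown sit.

The compounds shown leave open whether a longer chain such as butyl, or a chain ending in an amine, on this same oxygen would give a clearly lower number in this assay. They also leave open how far apart the ethoxy, propoxy and hydroxy compounds truly lie, since only compound 2 has an actual number.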